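Compound 2 and a Cyclopropyl Ketone in Place of the Ester

The source may report more compounds than this note shows. Statements on the series, on what has been measured and on what is new or still open speak of the compounds shown alone.

Measured so far:
compound 1 `COC(=O)C1=C(C)NC(=O)NC1c1ccoc1` gives 2%
compound 2 `COC(=O)C1=C(C)NC(=O)NC1c1cccs1` gives 3%
compound 3 `COC(=O)C1=C(C)N(C)C(=O)NC1c1cccs1` gives 15%

Of the compounds shown here, three sharing one core have been tested in an assay on membranes from HeLa cells for displacement of a labelled ligand from adenosine receptor A3 (Homo sapiens), read by scintillation counting, with a stated time of 180 min, tested at 1 uM; a lower number here means less inhibition, a higher number more inhibition at the concentration tested (going by the name of the read-out). Compound 2 stands second of the three numbers; its nearest neighbour is compound 1, and the step of a number 1 percentage points higher from compound 1 to compound 2 (within the scatter) lies within the scatter, so the two cannot be told apart. Going by the values given here, the only step beyond the scatter is a number 12 percentage points higher from compound 2 to compound 3 (beyond the scatter), a modest rise.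

The unmeasured compound 4 `CC1=C(C(=O)C2CC2)C(c2cccs2)NC(=O)N1` differs from compound 2 in one place: cyclopropyl in place of methoxy on a carbonyl carbon. Neither measured step bears on this change. The step of a number 1 percentage points higher from compound 1 to compound 2 (within the scatter) concerns the aromatic group on the saturated ring carbon, and the step of a number 12 percentage points higher from compound 2 to compound 3 (beyond the scatter) concerns the amide-type nitrogen; the methoxycarbonyl of compound 2 is untouched in both. There is therefore no measured guide for trading methoxycarbonyl for cyclopropylcarbonyl, and the low number of compound 2 leaves little room for a fall. The expectation is a step of a number 3 percentage points higher from compound 2 to compound 4 (within the scatter) that stays within the scatter. Compound 4 is estimated at 6% in this assay, with a range from -5% to 20%.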

Compound 4, a percentage reported as inhibition, at one concentration (the size of the read-out at that concentration, not a potency): 15%
The estimate for compound 4 lay 9 percentage points below the measured number, and the stated range covers the measured number.
By their numbers in this assay, from the lowest: compounds 1 and 2 (each within the scatter of the next); then compounds 3 and 4 (each within the scatter of the next).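

Going by these compounds alone, this is the first change at the carbonyl carbon whose other neighbour is the double-bonded ring carbon, and it shows that the methoxycarbonyl of compound 2 can be exchanged with a measurable result in this assay: cyclopropyl in place of methoxy gives a number 12 percentage points higher from compound 2 to compound 4 (beyond the scatter), a modest change at a single concentration that says nothing about potency. The earlier steps shown here had changed only the aromatic group on the saturated ring carbon and the amide-type nitrogen, so this result adds a second place on the shared core, after that nitrogen, where one change from compound 2 goes beyond the scatter. Nothing measured here accounts for the rise.

The exchange removes methoxy, with its oxygen, and brings in a three-membered carbon ring at the same time, so the compounds shown cannot separate what each part contributes. Also open, on these data alone, is how hydroxy, as in a carboxylic acid, an amine giving an amide, or a longer chain such as butyl would compare with cyclopropyl on this carbonyl carbon, and whether cyclopropylcarbonyl and the methyl on the amide-type nitrogen would add up in one compound.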